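The source may hold more compounds than are shown below. What is called first, only, known or untested is meant among the compounds shown, and "the series" means these compounds.

Compound 2 `Cc1c(OCCCCOc2ccccc2C(=O)O)ccc(C(=O)CC2CCCC2)c1O` has in an assay on HEK293 cells for positive allosteric modulation of metabotropic glutamate receptor 3 (Rattus norvegicus), read by thallium flux, with a stated time of 2.5 min (on this read-out higher numbers stand for an effect only at larger amounts of compound and lower numbers for an effect already at smaller amounts), no single number, only the entry "not determined" (no result reported). Compound 1 `Cc1c(OCCCCOc2ccccc2C(=O)O)ccc(C(=O)CC2CCCC2)c1C`, a near relative, likewise carries in this assay only "not determined" (no result reported). Among the measured compounds shown here, the only number belongs to compound 3 `CCCC(=O)c1ccc(OCCCCOc2cc(C(=O)O)ccc2OC)c(C)c1O`, which in this assay gives 496 nM. Compound 4 `Cc1cc(C(=O)O)ccc1OCCCCOc1ccc(C(=O)CC2CCCC2)c(O)c1C` arises from compound 2 by one change: 4-carboxy-2-methylphenyl in place of 2-carboxyphenyl on an oxygen on a saturated carbon. Since compound 2 stands without a value, the step to compound 4 has no measured start point, so no direction can be read from it; I expect no step beyond the usual scatter, and lean on compound 3, whose 496 nM shows a carboxy group set on the far ring in a comparable way. For compound 4 I therefore estimate a result in this assay of about 600 nM, expected to fall between 150 nM and 3000 nM.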

Compound 4, half-maximal effective concentration: > 10000 nM
Compound 4 was reported as a limit; the forecaster's own chance of this, stated with the estimate: 20%; middle value at least 16-fold (1.22 log units) away from the limit.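

No step can be read from compound 2 to compound 4 in this assay, as neither has a single number. Compound 4 gives > 10000 nM as a limit of the assay. Left open is how far 4-carboxy-2-methylphenyl in place of 2-carboxyphenyl shifts the effect.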